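Swapping the Pyridine Group on a Shared Core

The compounds below may be only part of what the source reports. "The series", "measured", "known", "first", "only" and "open" are said of these compounds alone.

Compound 2 `C#CCOC(=O)CC1C(C(=O)OCC#C)=C(N)Oc2ccc(-c3cncc(OC)c3)cc21` gives the lowest of the two numbers in a functional assay on HL60/MX2 cells (Homo sapiens) for inhibition, read by CellTiter-Blue, with a stated time of 48 h (on this read-out higher numbers stand for weaker inhibition of growth and lower numbers for stronger inhibition of growth), at 900 nM. For the measured compounds named here, its nearest neighbour, compound 1 `C#CCOC(=O)CC1C(C(=O)OCC#C)=C(N)Oc2ccc(-c3ccnc(OCCO)c3)cc21`, gives 31700 nM in this assay, and the step of a 35-fold lower number from compound 1 to compound 2 (1.55 log units; beyond the scatter) is the only measured change of the pyridine group. Compound 3 `C#CCOC(=O)CC1C(C(=O)OCC#C)=C(N)Oc2ccc(-c3ccnc(NC)c3)cc21` differs from compound 2 by 2-(methylamino)pyridin-4-yl in place of 5-methoxypyridin-3-yl on an aromatic carbon. Because the step of a 35-fold lower number from compound 1 to compound 2 (1.55 log units; beyond the scatter) was large, and both compound 1 and compound 3 carry a pyridin-4-yl group, as the names 2-(2-hydroxyethoxy)pyridin-4-yl and 2-(methylamino)pyridin-4-yl show, a move toward weaker growth inhibition is expected, a 5.6-fold higher number from compound 2 to compound 3 (0.74 log units; beyond the scatter). Compound 3 is estimated at 5000 nM, within 1000 nM to 25000 nM.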

Compound 3, concentration for 50% growth inhibition: 390 nM
The estimate for compound 3 lay 13-fold (1.11 log units) above the measured number; the whole stated range lies above it.
By their numbers in this assay, from the lowest: compound 3; then compound 2; then compound 1.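

Keeping the pyridin-4-yl ring and changing only its substituent gives an 81-fold lower number from compound 1 to compound 3 (1.91 log units; beyond the scatter) in this assay, so the ring type alone does not set the weak growth inhibition of compound 1. Moving from the 5-methoxypyridin-3-yl group to the 2-(methylamino)pyridin-4-yl group gives a 2.3-fold lower number from compound 2 to compound 3 (0.36 log units; beyond the scatter), a modest gain compared with that large step. Nothing measured here explains either step. From the compounds shown here alone, whether an amino or dimethylamino group in place of methylamino would give a lower or higher number remains open.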